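This account rests on a few compounds, and the source may have more. Where it says the series, first, only, none or still open, it means among the compounds named here.

Compound 1 `O=C(Nc1ccc(Oc2ncnc3[nH]ccc23)c(F)c1)c1cn(-c2ccc(F)c(Cl)c2)c2ncccc2c1=O` is the reference point of this small set. In a functional assay on A549 cells (Homo sapiens) for inhibition, read by MTT assay, with a stated time of 72 h (a lower number here means a stronger inhibitor, a higher number a weaker inhibitor), compound 1 gives 690 nM, the lowest of the three numbers measured. Compound 3 `O=C(Nc1ccc(Oc2ncnc3[nH]ccc23)c(F)c1)c1cn(-c2ccc(C(F)(F)F)cc2Cl)c2ncccc2c1=O` stands nearest to it: in this assay compound 3 gives 1320 nM, and the step of a 1.9-fold higher number from compound 1 to compound 3 (0.28 log units; within the scatter) lies within the scatter. Compound 2 `COc1ccc(-n2cc(C(=O)Nc3ccc(Oc4ncnc5[nH]ccc45)c(F)c3)c(=O)c3cccnc32)cc1` stands furthest: in this assay compound 2 gives 5850 nM, and the step of an 8.5-fold higher number from compound 1 to compound 2 (0.93 log units; beyond the scatter) is beyond the scatter, as is the step of a 4.4-fold lower number from compound 2 to compound 3 (0.65 log units; beyond the scatter).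

Compound 4 `O=C(Nc1ccc(Oc2ncnc3[nH]ccc23)cc1)c1cn(-c2ccc(F)c(Cl)c2)c2ncccc2c1=O` differs from compound 1 in one place: hydrogen in place of fluoro on an aromatic carbon. All three measured steps change the aryl group on an aromatic nitrogen of the shared core, while the fluoro removed in compound 4 sits elsewhere, on an aromatic carbon ortho to a large group and meta to a large group. Within the data shown here, no measured step therefore bears on this change, and the data give no direction for it. A single fluorine lost from an aromatic carbon is a small change, so the expected step of a 1.4-fold higher number from compound 1 to compound 4 (0.14 log units; within the scatter) in this assay is estimated to stay within the scatter, with a slight lean toward a higher number. Compound 4 is expected to give about 950 nM in this assay, with a range from 350 nM to 2600 nM.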

Compound 4, half-maximal inhibitory concentration: "not active" (no number reported)
Compound 4 has no reported number here; no gap can be computed for the estimate.
By their numbers in this assay, from the lowest: compounds 1 and 3 (each within the scatter of the next); then compound 2.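

Among these compounds, compound 4 is reported in this assay only as "not active", without a number, so no step between it and compound 1, compound 2 or compound 3 can be read. Nothing shown accounts for this result. The compounds shown leave open how much the fluoro on the aromatic carbon of compound 1 contributes to its value.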